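This account rests on a few compounds, and the source may have more. Where it says the series, first, only, none or still open, it means among the compounds named here.

Measured so far: compound 1 `COc1cc2c(=O)c(C(=O)c3ccc(C)cc3)cn(Cc3ccc(Cl)cc3)c2cc1OC` gives 15500 nM in an ADME assay on Huh-7 cells (Homo sapiens) for cytotoxicity; a lower number here means a stronger inhibitor of growth, a higher number a weaker inhibitor of growth. Compound 2 `COc1cc2c(=O)c(C(=O)c3ccc(C)cc3)cn(CCCc3ccccc3)c2cc1OC` is reported in this assay only as "not active" (no number reported), with no number. Compound 3 `CCOC(=O)c1cn(Cc2ccc(Cl)cc2)c2cc(OC)c(OC)cc2c1=O` reaches only a limit in this assay, > 15000 nM.

The account follows compound 2 to compound 4 `COc1cc2c(=O)c(C(=O)c3ccc(C)cc3)cn(Cc3ccc(C(C)(C)C)cc3)c2cc1OC`. Compound 2 stands without a number among the three values shown. The change is 4-(tert-butyl)phenyl in place of phenethyl on a saturated chain carbon bound to an aromatic nitrogen. Going by the values given here, no measured step covers this place; the single step, a step that the limit leaves unreadable from compound 1 to compound 3, alters the carbonyl side and cannot be read because of the limit of > 15000 nM in this assay, at which 1 of the 3 values shown sits. Compound 2 differs from compound 1 only at the saturated chain carbon bound to the aromatic nitrogen, and compound 1 gives 15500 nM. Compound 4 is therefore expected to stay weak, estimated at 20000 nM, between 8000 nM and 60000 nM, with a fair chance of a limit only.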

Compound 4, concentration for 50% growth inhibition: > 25000 nM
Compound 4 was reported as a limit; the forecaster's own chance of this, stated with the estimate: 50%; at least 1.2-fold (0.09 log units) between middle value and limit.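

In this assay compound 4 gives only a limit, > 25000 nM, so like compound 2 it has no exact number. Tert-butyl in place of chloro on an aromatic carbon gives an at least 1.6-fold higher number from compound 1 to compound 4 (0.20 log units; that floor lies within the scatter), so the step shows no gain in growth inhibition, but its true size cannot be read. With the 4-(tert-butyl)benzyl group, as with the 3-phenylpropyl group, no measurable growth inhibition is established. The compounds shown leave open whether an amine or a carboxylic acid in place of the tert-butyl on that aromatic carbon would give a lower number.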